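Swapping a methyl for a hydroxyl on a weak sulfonamide

A few compounds are considered here, and "the series" means these few. Any claim that something is new, unique, unknown or untested is made for them only; others in the source may bear on it.

Of the compounds shown here, three with a shared sulfonamide core have been measured in an assay on cells for inhibition of HSP60/HSP10 (Homo sapiens), with a stated time of 60 min; on this read-out higher numbers stand for weaker inhibition and lower numbers for stronger inhibition. Compound 1 `O=S(=O)(Nc1ccc(-c2nc3ccccc3o2)cc1)c1cccs1` gives 63000 nM. Compound 3 `C=Cc1ccc(S(=O)(=O)Nc2ccc(-c3nc4ccccc4o3)cc2)cc1` carries 4-vinylphenyl in place of thiophen-2-yl on the sulfonyl sulfur, and the result is an at least 1.5-fold higher number from compound 1 to compound 3 (0.20 log units; that floor lies within the scatter). For compound 3 this assay reports only the limit > 100000 nM. Compound 2 `Cc1ccccc1S(=O)(=O)Nc1ccc2oc(-c3ccccc3)nc2c1` also reaches only the limit > 100000 nM in this assay, so its true number is not known, only that it sits at the weak end of what has been seen here. Two of the three values sit at the limit of > 100000 nM in this assay, at which 2 of the 3 values shown sit.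

Compound 4 `O=S(=O)(Nc1ccc2oc(-c3ccccc3)nc2c1)c1cccc(O)c1` differs from compound 2 in one place: 3-hydroxyphenyl in place of 2-methylphenyl on a sulfonyl sulfur. Within the data shown here, no measured step swaps one six-membered aromatic ring for another on the sulfonyl sulfur of this core; the only step measured, an at least 1.5-fold higher number from compound 1 to compound 3 (0.20 log units; that floor lies within the scatter), belongs to a differently built core and lies within the scatter, so it gives little guidance. Compound 4 is therefore expected to remain close to the limit, with an expected step of a number no higher from compound 2 to compound 4 (the limit leaves the size open). The estimate for compound 4 is 100000 nM, with a range from 30000 nM to 300000 nM.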

Compound 4, half-maximal inhibitory concentration: 76000 nM
For compound 4 the middle estimate is 1.3-fold (0.12 log units) above the measured one; the measured number falls inside the stated range.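

Of the two compounds on this core, compound 4 is the one that gives a real number in this assay, so a sulfonamide carrying 3-hydroxyphenyl on the sulfonyl sulfur can be placed on the scale. Compound 2 gives > 100000 nM, which is a limit of the assay and not a number. The swap gives an at least 1.3-fold lower number from compound 2 to compound 4 (0.11 log units; that floor lies within the scatter), so nothing beyond the usual scatter can be claimed, and the true size of the step stays unknown because one end of it is a limit: the limit of > 100000 nM in this assay, at which 2 of the 4 values shown sit.

Two things differ at once in this swap, the methyl giving way to a hydroxyl and the number of its place on the ring, and 2-hydroxyphenyl or 3-methylphenyl on the same sulfur would tell these apart. Among these compounds, also open is whether an amine or a carboxylic acid in place of the hydroxyl would move the number on this core, where the one real value so far remains weak.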